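The compounds below may be only part of what the source reports. "The series", "measured", "known", "first", "only" and "open" are said of these compounds alone.

Compound 1 `O=C(/C=C/c1ccc(Cl)cc1)c1ccccc1` gives 16500 nM in a functional assay on HCT-116 cells (Homo sapiens) for inhibition, read by sulforhodamine B assay, with a stated time of 3 days; a lower number here means a stronger inhibitor of growth, a higher number a weaker inhibitor of growth.
Compound 2 `COc1cccc(/C=C/C(=O)c2ccc(OCc3ccccc3)cc2)c1` gives 35400 nM in this assay.
Compound 3 `COc1ccc(CCC(=O)c2ccccc2)cc1` gives a limit of > 100000 nM in this assay.

Of the two numbers in hand, compound 2 stands at the higher end, that is, it is the weaker inhibitor of growth of the two, and compound 1 stands at the lower end; the gap between them lies beyond the usual scatter of repeated measurements. For compound 3 the assay reports only a limit and no number (the limit of > 100000 nM in this assay, at which 1 of the 3 values shown sits).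

The unmeasured compound 4 `O=C(/C=C/c1ccccc1)c1ccc(OCc2ccccc2)cc1` differs from compound 2 in a single place: hydrogen in place of methoxy on an aromatic carbon. A methoxy group leaves and a hydrogen atom enters, on an aromatic carbon of a six-membered aromatic ring of carbon only, meta to a large group; cut one bond further out, 3-methoxyphenyl becomes phenyl.

For the measured compounds named here, none of the measured pairs covers this change, so no measured step guides the expectation. The step is expected to be small, most likely within the scatter, with a slight lean toward a lower number: a 1.3-fold lower number from compound 2 to compound 4 (0.10 log units; within the scatter) is the estimated change. Compound 4 is therefore expected to give about 28000 nM in this assay, with a likely range from 11000 nM to 75000 nM.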

Compound 4, concentration for 50% growth inhibition: > 50000 nM
Compound 4: no number, only a limit; the forecaster's own chance of this, stated with the estimate: 12%; middle value at least 1.7-fold (0.25 log units) from the limit.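

In this assay compound 4 gives no number, only a limit: the limit of > 50000 nM in this assay, at which 1 of the 4 values shown sits.

For the compounds shown here, replacing methoxy with hydrogen on this aromatic carbon gives an at least 1.4-fold higher number from compound 2 to compound 4 (0.14 log units; that floor lies within the scatter), the first step that can be read at all, since no earlier pair of compounds differed in one place. The step has a floor but no ceiling, and it shows that going from 3-methoxyphenyl to phenyl brings no stronger inhibition of growth at this position. Because that floor lies within the scatter, the result cannot separate a real loss on removing the methoxy group from no change, and a loss of any larger size remains equally possible.

The compounds shown leave open how a hydroxy group, an amine or a longer alkoxy chain on this same aromatic carbon would compare with methoxy in this assay. They also leave open whether the same change would read alike on the core of compound 1, where the other aromatic ring carries no benzyloxy group, and a measured number for compound 4 in place of its limit would be needed to size the step.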